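Cyclohexylamino to dipropylamino on a fused quinone core

The compounds below may be only part of what the source reports. "The series", "measured", "known", "first", "only" and "open" are said of these compounds alone.

Compound 1 `O=C1C=C(NC2CCCCC2)C(=O)c2c1nc1n2[C@H]2OC[C@@H](O)[C@H]2OC1` is the reference. In a functional assay on MCF7 cells (Homo sapiens) for inhibition, read by sulforhodamine B assay (a higher number here means a weaker inhibitor, a lower number a stronger inhibitor), compound 1 reads only a limit of > 8000 nM. Compound 2 `CCCN(CCC)C1=CC(=O)c2nc3n(c2C1=O)[C@H]1OC[C@@H](O)[C@H]1OC3` carries dipropylamino in place of cyclohexylamino on a double-bonded ring carbon. In this assay compound 2 also reads only a limit, > 16000 nM. The step that the two limits leave unreadable from compound 1 to compound 2 cannot be sized because the two values sit at the limit of > 16000 nM in this assay, at which 2 of the 3 values shown sit, and (the limit of > 8000 nM in this assay, at which 1 of the 3 values shown sits). Compound 3 `O=C1C(NC2CCCCC2)=CC(=O)c2c1nc1n2[C@H]2OC[C@@H](O)[C@H]2OC1` has the same atoms as compound 1 joined differently; the difference between the two cores is not broken down here. In this assay compound 3 again gives only a limit, > 16000 nM. Compound 4 `CCCN(CCC)C1=CC(=O)c2c(nc3n2[C@H]2OC[C@@H](O)[C@H]2OC3)C1=O` is not yet measured; from compound 3 it carries dipropylamino in place of cyclohexylamino on a double-bonded ring carbon, the same change as from compound 1 to compound 2, at the same place. The step that the limit leaves unreadable from compound 3 to compound 4 is expected to be small. Compound 4 is expected at 20000 nM, most likely reported once more only as a limit, within 8000 nM to 60000 nM, because compound 3 already sits at > 16000 nM.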

Compound 4, half-maximal inhibitory concentration: > 16000 nM
Compound 4 ended at the assay's limit (the forecaster's own chance of this, stated with the estimate: 85%); the middle value is on the limit's open side.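

Compound 3 and compound 4 yield no readable step in this assay, as both stand at a limit: the limit of > 16000 nM in this assay, at which 3 of the 4 values shown sit.

The compounds shown leave open how strongly any of them inhibits, and whether dipropylamino in place of cyclohexylamino changes that at all.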